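The compounds below may be only part of what the source reports. "The series", "measured", "known", "first", "only" and "open" are said of these compounds alone.

Measured so far:
compound 1 `Cc1cccc(-c2noc(C3CN(S(=O)(=O)c4cccc(C)c4)C3)n2)c1`, 650 nM
compound 2 `Cc1cccc(S(=O)(=O)N2CC(c3nc(-c4cccc(Cl)c4)no3)C2)c1`, 390 nM
compound 3 `Cc1cccc(-c2noc(C3CN(C(=O)C4CCC(C(F)(F)F)CC4)C3)n2)c1`, a limit only

The three compounds were read in an assay on HEK293 cells for negative allosteric modulation of metabotropic glutamate receptor 5 (Homo sapiens), read by FLIPR; on this read-out higher numbers stand for weaker inhibition and lower numbers for stronger inhibition. In this assay compound 1 gives 650 nM. Compound 2 carries the change chloro in place of methyl on an aromatic carbon and gives 390 nM. The step of a 1.7-fold lower number from compound 1 to compound 2 (0.22 log units; within the scatter) is therefore within the scatter. Compound 3 differs from compound 1 in the core, and the difference between the two cores is not broken down here. For compound 3 this assay reports only a limit, > 10000 nM, which is the limit of > 10000 nM in this assay, at which 1 of the 3 values shown sits.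

Compound 4 `O=C(C1CCC(C(F)(F)F)CC1)N1CC(c2nc(-c3cccc(Cl)c3)no2)C1` is not yet measured. It relates to compound 3 as compound 2 relates to compound 1: the change (chloro in place of methyl on an aromatic carbon), the same kind of change. Since the earlier step of a 1.7-fold lower number from compound 1 to compound 2 (0.22 log units; within the scatter) stayed within the scatter, a similarly small step is expected here, and compound 4 is expected to stay near the limit of compound 3, given that compound 3 gives > 10000 nM. The expected step for compound 4 is a step that the limit leaves unreadable from compound 3 to compound 4. The estimate for compound 4 in this assay is 12000 nM, between 4000 nM and 40000 nM, most likely reported again as a limit.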

Compound 4, half-maximal inhibitory concentration: > 10000 nM
Compound 4 ended at the assay's limit; the forecaster's own chance of this, stated with the estimate: 75%; the middle value does not contradict the limit.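

In this assay compound 3 gives > 10000 nM, which is a limit. Going by these compounds alone, compound 4 gives > 10000 nM, also a limit, so no step between compound 3 and compound 4 can be read. The compounds shown leave open what the change from 3-methylphenyl to 3-chlorophenyl does when it is carried by compound 3 and compound 4.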